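The compounds below may be only part of what the source reports. "The series", "measured", "known", "first", "only" and "open" are said of these compounds alone.

Series notes. Compound 1 `Cc1cc(NC(=O)Nc2ccccc2C(F)(F)F)c2ccccc2n1` is the reference. In an ADME assay on Raji cells (Homo sapiens) for cytotoxicity, with a stated time of 72 h (a lower number here means that less compound is needed, a higher number that more compound is needed for the effect), compound 1 reaches only a limit, > 25000 nM. Compound 2 `Cc1cc(NC(=O)Nc2ccc(Cl)cc2Cl)c2ccccc2n1` likewise gives only a limit in this assay, > 25000 nM. Compound 3 `COc1cccc(NC(=O)Nc2cc(C)nc3ccccc23)c1` also stops at a limit in this assay, > 25000 nM. Among the measured compounds shown here, all values so far share one feature, (the limit of > 25000 nM in this assay, at which 3 of the 3 values shown sit), so compound 1 stands level with the rest and no ranking among them can be read. Compound 4 `Cc1cc(NC(=O)Nc2ccccc2N)c2ccccc2n1` differs from compound 1 by amino in place of trifluoromethyl on an aromatic carbon. For the measured compounds named here, no measured step gives a scale for such a change. The expected step is a step that the limit leaves unreadable from compound 1 to compound 4, that is nothing beyond the scatter. Compound 4 is expected to give 30000 nM in this assay, with a range from 10000 nM to 100000 nM, most probably reported again only as a limit.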

Compound 4, half-maximal effective concentration: > 25000 nM
Compound 4 was reported as a limit; the forecaster's own chance of this, stated with the estimate: 80%; the middle value lies beyond the limit too.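

No step can be read between compound 1 and compound 4, as both stop at a limit: the limit of > 25000 nM in this assay, at which 4 of the 4 values shown sit. The compounds shown leave open whether any change on the shared core gives a readable value in this assay.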